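Notes on the terminal anilide variation in this series

The source may hold more compounds than are shown below. What is called first, only, known or untested is meant among the compounds shown, and "the series" means these compounds.

Three anilides on a shared core have numbers in a functional assay on A549 cells (Homo sapiens) for inhibition, read by CCK-8 assay, with a stated time of 72 h, tested at 1 uM; a lower number here means less inhibition of growth, a higher number more inhibition of growth at the concentration tested. Compound 1 `CN(C)C(=O)c1cc2cnc(Nc3ccc(NC(=O)C4(C(=O)Nc5ccccc5F)CC4)cc3)nc2n1C1CCCC1` gives 79.1%. Compound 2 `CN(C)C(=O)c1cc2cnc(Nc3ccc(NC(=O)C4(C(=O)Nc5cccc(Br)c5)CC4)cc3)nc2n1C1CCCC1` gives 20.2% in this assay. Compound 3 `Cc1ccc(NC(=O)C2(C(=O)Nc3ccc(Nc4ncc5cc(C(=O)N(C)C)n(C6CCCC6)c5n4)cc3)CC2)cc1` gives 40.2% in this assay, the second highest of the three numbers: a number 20 percentage points higher from compound 2 to compound 3 (beyond the scatter), while a number 38.9 percentage points lower from compound 1 to compound 3 (beyond the scatter). Each exchange of the aryl group on the amide-type nitrogen has so far moved the readout beyond the scatter, and in both directions.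

Compound 4 `CN(C)C(=O)c1cc2cnc(Nc3ccc(NC(=O)C4(C(=O)Nc5ccc(C(F)(F)F)cc5)CC4)cc3)nc2n1C1CCCC1` is not yet measured. It differs from compound 3 in one place: trifluoromethyl in place of methyl on an aromatic carbon. Going by the values given here, no measured step exchanges a group at that same aromatic carbon; the steps from compound 1 and from compound 2 to compound 3 replace the whole aryl ring, so they bear on this change only loosely, showing that this part of the molecule can shift the readout by large amounts without fixing the direction. The step from compound 3 to compound 4 is therefore expected to be small in its middle value, with a wide range on either side; the estimated step is a number 5.2 percentage points lower from compound 3 to compound 4 (within the scatter). For compound 4 in this assay the estimate is 35%, expected to fall between 10% and 65%.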

Compound 4, percent growth inhibition at one concentration: -25.3%
The estimate for compound 4 lay 60.3 percentage points above the measured number; measured number outside the range, below it.
By their numbers in this assay, from the lowest: compound 4; then compound 2; then compound 3; then compound 1.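

In this assay, a single exchange on the terminal ring is enough to give a large change. Trifluoromethyl in place of methyl, with the ring and the place para to a large group unchanged, gives a number 65.5 percentage points lower from compound 3 to compound 4 (beyond the scatter), so a large step here does not require replacing the whole aryl ring. The ring exchanges leading to the same anilide are also large, at a number 45.5 percentage points lower from compound 2 to compound 4 (beyond the scatter) and a number 104.4 percentage points lower from compound 1 to compound 4 (beyond the scatter), which leaves compound 4 at -25.3% as the lowest of the four, with its steps to all the others beyond the scatter, and no measurement available speaks to what lies behind this step.

From the compounds shown here alone, whether the low number is peculiar to trifluoromethyl or extends to other groups on that aromatic carbon remains open, and a methoxy group, a chlorine atom or an amine there would help separate these readings. Also open, going by these compounds, is whether the number of compound 1 depends on its fluorine at all, a question an unsubstituted phenyl ring would answer.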